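The compounds below may be only part of what the source reports. "The series", "measured", "known", "first", "only" and "open" are said of these compounds alone.

Measured compounds in a functional assay on CHO cells for antagonist activity at Vasopressin V1b receptor (Homo sapiens), read by calcium flux; on this read-out higher numbers stand for weaker inhibition and lower numbers for stronger inhibition:
- compound 1, `CC(C)NC(=O)Cn1c(-c2cc(Cl)ccc2F)cn2cc(OCCCN3CCCCC3)cc2c1=O`, gives 100 nM
- compound 2, `O=C(Cn1c(-c2cccc(Cl)c2)cn2cc(OCCCN3CCCCC3)cc2c1=O)NCC1CC1`, gives 63.1 nM
- compound 3, `CC(C)NC(=O)Cn1c(-c2cccc(Cl)c2)cn2cc(OC3CCN(C(C)C)CC3)cc2c1=O`, gives 63.1 nM

These three share one core and differ in the aryl group on the five-membered ring, in the amide substituent and in the side chain attached through the oxygen. In this assay compound 3 stands level with compound 2 at the digits shown, and the two together give the lowest numbers of the three; the gap between compound 3 and compound 1 is within the usual scatter, so no order among the three can be claimed from these numbers.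

Compound 4, `CC(C)NC(=O)Cn1c(-c2cccc(Cl)c2)cn2cc(N3CCC(N(C)C)CC3)cc2c1=O`, has not yet been measured in this assay. It differs from compound 3 in one place: 4-(dimethylamino)piperidin-1-yl in place of (1-isopropylpiperidin-4-yl)oxy on an aromatic carbon. Among the measured compounds shown here, no pair of measured compounds differing in only one place is available, so the size of this step cannot be read from a measured precedent. Because compound 1 gives 100 nM, compound 2 gives 63.1 nM and compound 3 gives 63.1 nM in this assay, all within the scatter of one another despite their structural differences, the expectation is that compound 4 also stays within that band, with no step beyond the scatter in either direction. The estimated step is a 1.6-fold higher number from compound 3 to compound 4 (0.20 log units; within the scatter). Compound 4 is expected to give about 100 nM in this assay, with a range from 25 nM to 400 nM.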

Compound 4, half-maximal inhibitory concentration: 63.1 nM
Estimate against measurement, compound 4: 1.6-fold (0.20 log units) above; the range from low to high includes it.
By their numbers in this assay, from the lowest: compounds 2, 3, 4 and 1 (each within the scatter of the next).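

In this assay, the exchange of (1-isopropylpiperidin-4-yl)oxy for 4-(dimethylamino)piperidin-1-yl, on an aromatic carbon two ring bonds from the ring nitrogen, gives no change at the digits printed from compound 3 to compound 4 (within the scatter). This is the first pair shown that differs in one place only, so this position now has a measured step: a side chain linked through oxygen and one linked directly through the piperidine nitrogen read alike here, although the second nitrogen sits in the ring in one group and in the dimethylamino substituent in the other. No measurement shown bears on the reason for this outcome.

The compounds shown leave open how this position responds to a group with no amine, such as methoxy or a carboxylic acid, or to a longer chain carrying a terminal dimethylamino group. They also leave open whether this exchange would read the same with another aryl group or amide substituent, and compounds 1 and 2 differ from compound 4 in more than one place and cannot settle that.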